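Cyclohexyl for methyl on an aromatic nitrogen: cytotoxicity

The source may report more compounds than this note shows. Statements on the series, on what has been measured and on what is new or still open speak of the compounds shown alone.

Measured so far:
compound 1 `CCC(=O)Nc1ccc(-c2nc3cc(C(F)(F)F)ccc3n2C2CCCCC2)cc1` — > 100000 nM
compound 2 `CC(=O)Nc1ccc(-c2nc3cc(C(F)(F)F)ccc3n2C)cc1` — > 100000 nM

In an ADME assay on Vero cells (Chlorocebus sabaeus) for cytotoxicity (a lower number here means that less compound is tolerated, a higher number that more compound is tolerated), compound 1 reaches a limit of the assay, reported as > 100000 nM. In this assay compound 2 likewise reaches a limit of the assay, reported as > 100000 nM. Compound 2 thus stands where every value shown stands, at the limit of > 100000 nM in this assay, at which 2 of the 2 values shown sit, and nothing in the numbers separates it from compound 1.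

Compound 3 `CC(=O)Nc1ccc(-c2nc3cc(C(F)(F)F)ccc3n2C2CCCCC2)cc1` is not yet measured. It differs from compound 2 in one place: cyclohexyl in place of methyl on an aromatic nitrogen. Within the data shown here, no step between measured compounds is available for this change. Among the measured compounds shown here, compound 1, which already carries the cyclohexyl on that nitrogen, gives > 100000 nM, and that is the only guide for compound 3. The expected step of a number no higher from compound 2 to compound 3 (the limit leaves the size open) is none beyond the scatter. Compound 3 is therefore estimated at 100000 nM, within 50000 nM to 200000 nM, and most likely to come back as a limit rather than a number.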

Compound 3, half-maximal cytotoxic concentration: 30000 nM
For compound 3 the middle estimate is 3.3-fold (0.52 log units) above the measured one, and the stated range ends above it.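

In this assay the change on the aromatic nitrogen now has a readable direction, with an at least 3.3-fold lower number from compound 2 to compound 3 (0.52 log units; beyond the scatter). Cyclohexyl on that nitrogen does not by itself keep a compound at the limit, since the two compounds carrying it part on the other side of the molecule: hydrogen in place of methyl on the saturated chain carbon bound to the carbonyl carbon gives an at least 3.3-fold lower number from compound 1 to compound 3 (0.52 log units; beyond the scatter). Both steps are bounds and not sizes, since each has a limit at one end: the limit of > 100000 nM in this assay, at which 2 of the 3 values shown sit.

As far as these compounds go, the true size of either step stays open, and so does whether the lower number needs cyclohexyl as such. An isopropyl or a phenyl on the aromatic nitrogen, or a longer chain on the carbonyl, would show how far either trend extends.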